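Methoxy to phenoxy: the step from compound 3 to compound 4

The source may report more compounds than this note shows. Statements on the series, on what has been measured and on what is new or still open speak of the compounds shown alone.

Compound 3 `COc1ccc(CNc2ccc(CCC(=O)O)cc2)cc1` in a functional assay for agonist activity at Free fatty acid receptor 1 (Homo sapiens) (on this read-out higher numbers stand for an effect only at larger amounts of compound and lower numbers for an effect already at smaller amounts), gives 1260 nM, the higher of the two numbers in hand; the nearest is compound 1 `O=C(O)CCc1ccc(NCc2ccc(Cl)cc2)cc1` with 1000 nM, the step of a 1.3-fold higher number from compound 1 to compound 3 (0.10 log units; within the scatter). Compound 2 `N#Cc1ccc(CNc2ccc(CCC(=O)O)cc2)cc1` gives only a limit, < 31700 nM, so the steps a step that the limit leaves unreadable from compound 1 to compound 2 and a step that the limit leaves unreadable from compound 2 to compound 3 cannot be sized. Compound 4 `O=C(O)CCc1ccc(NCc2ccc(Oc3ccccc3)cc2)cc1` differs from compound 3 by phenyl in place of methyl on an oxygen on an aromatic ring. Going by the values given here, no measured step changes this position in the same way; the one readable step, from chloro to methoxy, stayed within the scatter. The expectation for compound 4 is therefore a modest gain, a 2.5-fold lower number from compound 3 to compound 4 (0.40 log units; beyond the scatter), with wide uncertainty. Compound 4 is estimated at 500 nM, between 120 nM and 2500 nM.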

Compound 4, half-maximal effective concentration: 195 nM
Beside the measured number, compound 4's estimate is 2.6-fold (0.41 log units) above it; measured number inside the range.
By their numbers in this assay, from the lowest: compound 4; then compounds 1 and 3 (each within the scatter of the next).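

In this assay this position gives its first readable change beyond the scatter: phenyl in place of methyl on the oxygen gives a 6.5-fold lower number from compound 3 to compound 4 (0.81 log units; beyond the scatter) and phenoxy in place of chloro gives a 5.1-fold lower number from compound 1 to compound 4 (0.71 log units; beyond the scatter) while chloro to methoxy stayed within the scatter. Compound 2 stands only as a limit, so the step from compound 2 to compound 4 cannot be read. Nothing shown bears on a cause for this gain.

Open: whether a benzyloxy group or a pyridyloxy ring in place of phenoxy keeps the gain, and whether a substituent on the phenyl ring adds to it.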